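Methyl for chloro on a benzyl group, in two settings

The source may hold more compounds than are shown below. What is called first, only, known or untested is meant among the compounds shown, and "the series" means these compounds.

Compound 1 `Nc1ncn(Cc2cccc(Cl)c2)c2ncnc1-2`, compound 2 `Nc1ncn(Cc2ccc(Cl)cc2)c2ncnc1-2` and compound 3 `Cc1cccc(Cn2cnc(N)c3ncnc2-3)c1` share one core and were tested in an assay on isolated protein (adrenal medulla) for inhibition of Dopamine beta-hydroxylase (Bos taurus); a higher number here means a weaker inhibitor, a lower number a stronger inhibitor. In this assay compound 1 gives 2 ug/mL, compound 2 gives 20 ug/mL and compound 3 gives 20 ug/mL. Compound 1 and compound 2 contain the same atoms joined differently; the difference between the two cores is not broken down here. Compound 2 and compound 3 stand level at the digits recorded, within the usual scatter, and together they are the highest of the three numbers. Within the data shown here, the only change measured in a single place is methyl in place of chloro on an aromatic carbon, which produced a 10-fold higher number from compound 1 to compound 3 (1.00 log units; beyond the scatter).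

Compound 4 `Cc1ccc(Cn2cnc(N)c3ncnc2-3)cc1` has not yet been measured in this assay. It differs from compound 2 by methyl in place of chloro on an aromatic carbon. Among the measured compounds shown here, this is the same kind of change as the one from compound 1 to compound 3, but not the same: in compound 3 the methyl sits meta to a large group, in compound 4 para to a large group. For the measured compounds named here, the only guide is the earlier step, a 10-fold higher number from compound 1 to compound 3 (1.00 log units; beyond the scatter), which went beyond the scatter. Because compound 2 already starts at 20 ug/mL, the step from compound 2 to compound 4 is expected to be of similar direction but is estimated somewhat smaller, at a 4.0-fold higher number from compound 2 to compound 4 (0.60 log units; beyond the scatter). Compound 4 is therefore estimated to give 80 ug/mL, with an expected range from 25 ug/mL to 300 ug/mL.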

Compound 4, half-maximal inhibitory concentration: 20 ug/mL
Beside the measured number, compound 4's estimate is 4.0-fold (0.60 log units) above it, outside the stated range (below it).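

In this assay, methyl in place of chloro on an aromatic carbon, para to a large group, gives no change at the digits printed from compound 2 to compound 4 (within the scatter), so on this core the swap leaves the number where it was. Set beside the earlier step, the same change did not carry over from one core to the other with the same size: the same change on two cores in this assay, a 10-fold higher number (1.00 log units; beyond the scatter) from compound 1 to compound 3 and no change at the digits printed (within the scatter) from compound 2 to compound 4, 10-fold (1.00 log units) apart, beyond the scatter of two such steps This shows that in this series a step read on one core cannot simply be transferred to the other, yet it does not show what separates the two results, and with a single pair on each core it gives no rule for any further core.

The compounds shown leave open how other groups in the same place on the benzyl ring, such as a methoxy group, a fluoro group, an amine or a carboxylic acid, would behave in this assay on each of the two cores. They also leave open whether a longer chain between the benzyl ring and the shared core would keep the two cores as far apart in their response to this swap as they are here.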